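Benzylic substituent series on the tribromocatechol core

A few compounds are considered here, and "the series" means these few. Any claim that something is new, unique, unknown or untested is made for them only; others in the source may bear on it.

Measured compounds:
- compound 1, `O=C1CCCN1Cc1c(Br)c(O)c(O)c(Br)c1Br`, 18500 nM
- compound 2, `CS(=O)(=O)Cc1c(Br)c(O)c(O)c(Br)c1Br`, 24000 nM
- compound 3, `COCc1c(Br)c(O)c(O)c(Br)c1Br`, 15500 nM

In a functional assay (on this read-out higher numbers stand for weaker inhibition and lower numbers for stronger inhibition), compound 3 gives the lowest of the three numbers, but its neighbours sit within the scatter: a 1.2-fold lower number from compound 1 to compound 3 (0.08 log units; within the scatter) and a 1.5-fold lower number from compound 2 to compound 3 (0.19 log units; within the scatter) are both steps no larger than repeat measurements of this kind; a 1.3-fold higher number from compound 1 to compound 2 (0.11 log units; within the scatter) likewise. None of the three compounds can be called stronger or weaker than another.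

Compound 4, `Cc1c(Br)c(O)c(O)c(Br)c1Br`, differs from compound 3 as follows: hydrogen in place of methoxy on a saturated chain carbon bound to an aromatic carbon. The bearing steps are those already made on the same saturated chain carbon, where three quite different groups gave numbers that lie within the scatter of one another. Replacing that group with hydrogen is a further change at the same place, and the shared core with its bromines and hydroxyls is untouched. The expectation in this assay is therefore no step beyond the scatter: the estimated step is a 1.0-fold higher number from compound 3 to compound 4 (0.01 log units; within the scatter). Compound 4 is expected at about 16000 nM, with a range of 7000 nM to 36000 nM.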

Compound 4, half-maximal inhibitory concentration: 14000 nM
For compound 4 the middle estimate is 1.1-fold (0.06 log units) above the measured one; low and high end bracket the measured number.
By their numbers in this assay, from the lowest: compounds 4, 3, 1 and 2 (each within the scatter of the next).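

In this assay, compound 4, with hydrogen in place of the group on the saturated chain carbon bound to an aromatic carbon, stays within the scatter of all three substituted compounds (a 1.1-fold lower number from compound 3 to compound 4 (0.04 log units; within the scatter); a 1.7-fold lower number from compound 2 to compound 4 (0.23 log units; within the scatter); a 1.3-fold lower number from compound 1 to compound 4 (0.12 log units; within the scatter)). The earlier compounds shown here compared three groups only with one another, whereas this result adds the unsubstituted case: methoxy, methylsulfonyl and 2-oxopyrrolidin-1-yl are each indistinguishable from hydrogen at this place on this read-out. No available evidence explains this flat result.

From the compounds shown here alone, whether an amine, a carboxylic acid or a longer chain at this place would give a step beyond the scatter remains open. Also open, going by these compounds, is how the numbers depend on the bromines and hydroxyls of the shared core, which are the same in all four compounds.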